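A few compounds are considered here, and "the series" means these few. Any claim that something is new, unique, unknown or untested is made for them only; others in the source may bear on it.

The study follows a small set of amides sharing a common core, read out in a functional assay on CHO cells for inhibition of transient receptor potential cation channel subfamily V member 1 (Homo sapiens); on this read-out lower numbers stand for stronger inhibition and higher numbers for weaker inhibition. For the measured compounds named here, compound 1 `CN(C(=O)/C=C/c1ccc(C(C)(C)C)cc1)c1ccc2c(c1)OCCO2` is the one member that does not reach a number: in this assay compound 1 gives only a limit, > 4000 nM. Compound 2 `CC(C)(C)c1ccc(/C=C/C(=O)Nc2ccc3c(c2)NCCC3)cc1` is built on a different core and in this assay gives 160 nM. Compound 3 `Cc1ccc(/C=C/C(=O)Nc2ccc3c(c2)OCCO3)cc1` keeps the core of compound 1; in this assay compound 3 gives 1100 nM, the higher of the two numbers recorded so far; the nearest neighbour is compound 2, which lies a clear distance lower, beyond the scatter.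

Compound 4 `O=C(/C=C/c1ccc(F)cc1)Nc1ccc2c(c1)OCCO2` has not yet been measured. It differs from compound 3 in a single place: fluoro in place of methyl on an aromatic carbon. Going by the values given here, no pair of measured compounds isolates this exchange, so the step from compound 3 to compound 4 has no counterpart in the numbers at hand. The expectation is that the step of a 1.4-fold higher number from compound 3 to compound 4 (0.13 log units; within the scatter) stays within the usual scatter, with at most a modest drift towards weaker inhibition. For compound 4 the estimated value in this assay is 1500 nM, with a range from 600 nM to 4000 nM.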

Compound 4, half-maximal inhibitory concentration: > 4000 nM
Compound 4: a limit, no number; the forecaster's own chance of this, stated with the estimate: 15%; at least 2.6-fold (0.42 log units) between middle value and limit.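

Exchanging 4-methylphenyl for 4-fluorophenyl, on the aromatic carbon para to a large group, gives an at least 3.6-fold higher number from compound 3 to compound 4 (0.56 log units; beyond the scatter), so in this assay the swap of one heavy atom at this position is enough to carry the read-out beyond the scatter. For the compounds shown here, this is the first single-place step, and it shows that this position is not indifferent to the group it carries, with the fluoro compound on the weaker side of the methyl compound. Compound 4 gives only a limit, so the step has a floor but no upper end, and its full size cannot be read at a value that is not unique to compound 4: the limit of > 4000 nM in this assay, at which 2 of the 4 values shown sit.

Open, on these data alone, is how other groups at this same place would read, such as chloro, methoxy, an amine or a carboxylic acid, and so whether the methyl group or the fluoro group is the unusual one here. Also open, as far as these compounds go, is whether the same exchange would give a step of similar size on the core of compound 2, where the read-out starts from a stronger value.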